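Swapping the amide-bound bicyclic group for a benzotriazole

The compounds below may be only part of what the source reports. "The series", "measured", "known", "first", "only" and "open" are said of these compounds alone.

Measured so far:
Compound 1 `COC(=O)c1ccc(N(Cc2cnc(C3CCCCC3)cn2)C(=O)[C@H]2CCN2S(=O)(=O)c2c(F)c(F)c(F)c(F)c2F)c(F)c1` — 1400 nM
Compound 2 `O=C1OCc2cc(N(Cc3ccc(C4CCCCC4)cn3)C(=O)[C@H]3CCN3S(=O)(=O)c3c(F)c(F)c(F)c(F)c3F)ccc21` — 900 nM

In a functional assay on MDA-MB-231 cells (Homo sapiens) for antiproliferative activity, with a stated time of 72 h (a higher number here means that more compound is needed for the effect, a lower number that less compound is needed), compound 2 gives 900 nM, the lower of the two numbers, and in this assay compound 1 gives 1400 nM, a gap that stays within the scatter, so no order between them is claimed. Compound 3 `O=C([C@H]1CCN1S(=O)(=O)c1c(F)c(F)c(F)c(F)c1F)N(Cc1ccc(C2CCCCC2)cn1)c1ccc2nn[nH]c2c1` differs from compound 2 in one place: a group of 9 heavy atoms (6 carbon, 3 nitrogen; one five-membered aromatic ring with 3 hetero atoms, one six-membered aromatic ring of carbon only) in place of a group of 10 heavy atoms (8 carbon, 2 oxygen; one five-membered non-aromatic ring with 1 hetero atom, one six-membered aromatic ring of carbon only), on an amide-type nitrogen. Among the measured compounds shown here, no measured pair shows this kind of change, so the step is expected to stay within the scatter, with no clear direction; the step of no change at the digits printed from compound 2 to compound 3 (within the scatter) is the estimate. Compound 3 is expected to give 900 nM, between 300 nM and 2700 nM.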

Compound 3, half-maximal effective concentration: 6600 nM
Compound 3: the middle estimate sits 7.3-fold (0.87 log units) below what was measured; the whole stated range lies below it.
By their numbers in this assay, from the lowest: compounds 2 and 1 (each within the scatter of the next); then compound 3.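

On the amide-type nitrogen, replacing the group with a five-membered non-aromatic ring by the one with a five-membered aromatic ring with 3 hetero atoms gives a 7.3-fold higher number from compound 2 to compound 3 (0.87 log units; beyond the scatter) in this assay. Among the compounds shown here, this shows that the response in this assay depends on the group at this position, which the earlier compounds could not show. The change also adds a hydrogen-bond donor, but no data here explain the step.

The compounds shown leave open whether the added donor or the change of ring matters more. They also leave open how a carboxylic acid or a primary carboxamide on the six-membered aromatic ring would compare with compound 2.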